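Cyclopropyl in place of 4-methoxyphenyl on compound 3

This account rests on a few compounds, and the source may have more. Where it says the series, first, only, none or still open, it means among the compounds named here.

In an ADME assay on GES1 cells (Homo sapiens) for inhibition, read by MTT assay, with a stated time of 72 h (on this read-out lower numbers stand for stronger inhibition and higher numbers for weaker inhibition), compound 3 `COc1ccc(CSc2nc3nc(C)cc(Nc4cc(-c5ccccc5)[nH]n4)n3n2)cc1` gives 28200 nM and thereby sits within the usual scatter of compound 1 `Cc1cc(Nc2cc(-c3ccccc3)[nH]n2)n2nc(SCCCc3ccccc3)nc2n1` at 40200 nM and compound 2 `Cc1cc(Nc2cc(-c3ccccc3)[nH]n2)n2nc(SCc3nc4ccccc4[nH]3)nc2n1` at 27800 nM without any rank among them. The next step leads to compound 4 `Cc1cc(Nc2cc(-c3ccccc3)[nH]n2)n2nc(SCC3CC3)nc2n1`, with cyclopropyl in place of 4-methoxyphenyl on a saturated chain carbon bound to a sulfur. Three exchanges at this same place bear on it: a 1.4-fold lower number from compound 1 to compound 2 (0.16 log units; within the scatter) and a 1.4-fold lower number from compound 1 to compound 3 (0.15 log units; within the scatter) and a 1.0-fold higher number from compound 2 to compound 3 (0.01 log units; within the scatter) all remain within the scatter. Among the measured compounds shown here, these exchanges cover phenethyl, 1H-benzimidazol-2-yl and 4-methoxyphenyl only, so no measured compound shows what cyclopropyl does here, and the flat record is weak support. No step beyond the scatter is expected in this assay, and the estimated step is a 1.2-fold higher number from compound 3 to compound 4 (0.07 log units; within the scatter) with no firm direction. The estimate for compound 4 is 33000 nM within an expected range of 16000 nM to 68000 nM for repeated measurements.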

Compound 4, half-maximal inhibitory concentration: > 50000 nM
Compound 4: only a limit was reported; the forecaster's own chance of this, stated with the estimate: 10%; middle value at least 1.5-fold (0.18 log units) away from the limit.
By their numbers in this assay, from the lowest: compounds 2, 3 and 1 (each within the scatter of the next). At a limit, above all of these: compound 4.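

In this assay, among the compounds shown here, compound 4 gives only a limit, > 50000 nM, the one value in this set that is not a number. Read as floors, the steps are an at least 1.7-fold higher number from compound 3 to compound 4 (0.24 log units; that floor lies within the scatter), an at least 1.7-fold higher number from compound 2 to compound 4 (0.25 log units; that floor lies within the scatter) and an at least 1.2-fold higher number from compound 1 to compound 4 (0.09 log units; that floor lies within the scatter), so no step beyond the scatter is shown, though the true distance of compound 4 stays unread. On a saturated chain carbon bound to a sulfur, the three groups carrying an aromatic ring all give numbers, while cyclopropyl, with its three-membered non-aromatic ring, gives a limit; this rests on compound 4 alone.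

As far as these compounds go, whether a limit goes with the non-aromatic ring or with the smaller group stays open. A cyclohexyl ring, a plain propyl chain or a chain ending in an amine at this place would help separate the two.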